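A Fluoro Step on a Hydroxy Compound

The source may hold more compounds than are shown below. What is called first, only, known or untested is meant among the compounds shown, and "the series" means these compounds.

In a functional assay (on this read-out lower numbers stand for stronger inhibition and higher numbers for weaker inhibition), compound 1 (`CC(C)=CCOc1ccc2c(c1)OC(c1ccccc1)CC2=O`) gives 6070 nM and compound 2 (`CC(C)=CCOc1ccc2c(c1)OC(c1cccc(F)c1)CC2=O`) gives 4280 nM while compound 3 (`CC(C)=CCOc1cc(O)c2c(c1)OC(c1ccccc1)CC2=O`) gives 7320 nM and so stands within the scatter of both others. The change leading to compound 4 (`CC(C)=CCOc1cc(O)c2c(c1)OC(c1cccc(F)c1)CC2=O`) is fluoro in place of hydrogen on an aromatic carbon and it turns phenyl to 3-fluorophenyl. The same replacement, made without the hydroxy group, appears as a 1.4-fold lower number from compound 1 to compound 2 (0.15 log units; within the scatter) and the hydroxy replacement itself appears as a 1.2-fold higher number from compound 1 to compound 3 (0.08 log units; within the scatter) so neither step leaves the scatter. No step beyond the scatter is therefore expected in this assay here. The step expected is a 1.3-fold lower number from compound 3 to compound 4 (0.12 log units; within the scatter) in size. Compound 4 is estimated at 5600 nM with 3400 nM to 9200 nM as its expected range.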

Compound 4, half-maximal inhibitory concentration: 7240 nM
For compound 4 the middle estimate is 1.3-fold (0.11 log units) below the measured one; low and high end bracket the measured number.
By their numbers in this assay, from the lowest: compounds 2, 1, 4 and 3 (each within the scatter of the next).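

With the hydroxy group in place, phenyl to 3-fluorophenyl gives a 1.0-fold lower number from compound 3 to compound 4 (0.00 log units; within the scatter), so in this assay the fluoro step has now been read on two cores: the same change on two cores in this assay, a 1.4-fold lower number (0.15 log units; within the scatter) from compound 1 to compound 2 and a 1.0-fold lower number (0.00 log units; within the scatter) from compound 3 to compound 4, 1.4-fold (0.15 log units) apart, within the scatter of two such steps. Among these compounds, the hydroxy replacement, read for the first time on the 3-fluorophenyl core, gives a 1.7-fold higher number from compound 2 to compound 4 (0.23 log units; within the scatter), and it too can be compared across two cores: the same change on two cores in this assay, a 1.2-fold higher number (0.08 log units; within the scatter) from compound 1 to compound 3 and a 1.7-fold higher number (0.23 log units; within the scatter) from compound 2 to compound 4, 1.4-fold (0.15 log units) apart, within the scatter of two such steps. Neither change leaves the scatter on either core.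

On these data alone, whether trifluoromethyl or an amine on the same aromatic carbon, or a methoxy group in place of the hydroxy group, would give a step beyond the scatter stays open.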